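A few compounds are considered here, and "the series" means these few. Any claim that something is new, unique, unknown or untested is made for them only; others in the source may bear on it.

Compound 3, `COc1ccc(-c2cnc(NC(=O)c3cnco3)n2C)cc1`, is one of three measured compounds in a toxicity assay on THP-1 cells (Homo sapiens) for inhibition; on this read-out higher numbers stand for lower toxicity in this test and lower numbers for higher toxicity in this test. In this assay compound 3 reaches only the limit > 100000 nM, a ceiling rather than a measured number. The same is true of compound 1, `Cn1c(-c2ccccc2F)cnc1NC(=O)c1ccc(F)cc1`, whose value in this assay is the limit > 100000 nM. Among the compounds with values here, compound 2, `Cn1c(-c2ccc(Cl)cc2)cnc1NC(=O)c1ccc(F)cc1`, is the one compound with a measured number, 37000 nM in this assay. Between these two lies the single counted step, an at least 2.7-fold lower number from compound 1 to compound 2 (0.43 log units; beyond the scatter), so swapping one halogen-bearing ring for another on an aromatic carbon moved the number downward, toward greater toxicity. Two of the three values sit at the limit of > 100000 nM in this assay, at which 2 of the 3 values shown sit, so little can be said about how much of the scale is actually used.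

The step to compound 4, `COc1ccc(-c2cnc(NC(=O)c3cccc(Cl)c3)n2C)cc1`, is a different kind of change: 3-chlorophenyl in place of 1,3-oxazol-5-yl on a carbonyl carbon. Within the data shown here, no measured pair shares this exact exchange on the carbonyl carbon, so the step from compound 1 to compound 2 is only an indirect hint that bringing in a chlorine-bearing ring can lower the number. On that basis, a small to modest downward move is expected, an at least 1.6-fold lower number from compound 3 to compound 4 (0.22 log units; that floor lies within the scatter), and compound 4 is estimated at 60000 nM, within 20000 nM to 150000 nM, with a fair chance that the assay again reports only its limit.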

Compound 4, half-maximal cytotoxic concentration: > 28000 nM
Compound 4 ended at the assay's limit; the forecaster's own chance of this, stated with the estimate: 40%; the middle value is on the limit's open side.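

In this assay compound 3 and compound 4 are both recorded only as limits of the assay, not as numbers, and the step between them cannot be read. The compounds shown leave open whether 3-chlorophenyl in place of 1,3-oxazol-5-yl on the carbonyl carbon changes the toxicity in this test at all.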